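The source may report more compounds than this note shows. Statements on the series, on what has been measured and on what is new or still open speak of the compounds shown alone.

Working notes on the series. Going by the values given here, in a functional assay on MIA PaCa-2 cells (Homo sapiens) for antiproliferative activity, read by sulforhodamine B assay, with a stated time of 48 h (on this read-out lower numbers stand for stronger inhibition and higher numbers for weaker inhibition), compound 2 (`COc1cc(OC)c2sc(-c3ccc(N/C=C\C(=O)c4ccc(OC)c(O)c4)cc3)nc2c1`) gives 11600 nM, the lower of the two numbers so far. Compound 1 (`COc1ccc(C(=O)/C=C\Nc2ccc(-c3nc4cc(OC)c(OC)c(OC)c4s3)cc2C)cc1O`) gives 15400 nM, which lies within the scatter of the compound 2 figure, so the two cannot be separated and neither stands out as the better compound.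

Compound 3 (`COc1ccc(C(=O)/C=C\Nc2ccc(-c3nc4cc(OC)c(OC)c(OC)c4s3)cc2)cc1O`) has not yet been measured. It differs from compound 2 by methoxy in place of hydrogen on an aromatic carbon.

Among the compounds with values here, no measured pair isolates this change, so the only guide is indirect. Compound 3 lacks a methyl group found in compound 1, but compound 1 also carries the entering methoxy, and compound 1 still reads 15400 nM. On that basis, no shift beyond the scatter is expected in this assay, and no firm direction can be assigned. The expected step is a 1.0-fold higher number from compound 2 to compound 3 (0.01 log units; within the scatter), a small one. In this assay the estimated value for compound 3 is 12000 nM, with an expected range of 4500 nM to 30000 nM.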

Compound 3, half-maximal inhibitory concentration: 32800 nM
Compound 3: middle estimate off by 2.7-fold (0.44 log units), on the low side; the measured number lies above the stated range.
By their numbers in this assay, from the lowest: compounds 2 and 1 (each within the scatter of the next); then compound 3.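

In this assay, going by these compounds alone, methoxy in place of hydrogen on an aromatic carbon, ortho to two methoxy groups, gives a 2.8-fold higher number from compound 2 to compound 3 (0.45 log units; beyond the scatter), which is the first sign that this position does not tolerate every change and that the methoxy here goes with weaker inhibition when nothing else differs. The methyl group seen in compound 1 also matters, as hydrogen in place of methyl on an aromatic carbon gives a 2.1-fold higher number from compound 1 to compound 3 (0.33 log units; beyond the scatter), and with both steps beyond the scatter, compound 3 is the weakest of the three compounds. Nothing measured here gives a reason for either step.

On these data alone, whether a hydroxyl or an ethoxy group at the position ortho to two methoxy groups would read like the methoxy or like hydrogen stays open, so the step cannot yet be tied to the size or the kind of group. As far as these compounds go, it is equally open whether chlorine or a longer chain such as ethyl, in place of the methyl of compound 1, would keep the number of compound 1 or move it.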